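A few compounds are considered here, and "the series" means these few. Any claim that something is new, unique, unknown or untested is made for them only; others in the source may bear on it.

Among the compounds with values here, compound 2, `Cc1nn(-c2ccccn2)c2cc(-c3ccc(CCC(=O)O)cc3F)ccc12`, is the point of departure, and it stands at the top of the two numbers measured so far. In a functional assay on cells for agonist activity at Free fatty acid receptor 1 (Mus musculus), read by FLIPR and calcium flux, with a stated time of 5 min (a lower number here means a smaller maximal response, a higher number a larger maximal response), compound 2 gives 105%, with compound 1, `Cc1nn(-c2ccccn2)c2cc(-c3ccc(CCC(=O)O)cc3)ccc12`, as its nearest neighbour. In this assay compound 1 gives 95%, and the step of a number 10 percentage points higher from compound 1 to compound 2 (within the scatter) lies within the usual scatter of such measurements. Compound 3, `Cc1nn(-c2ccccn2)c2cc(-c3ccc(CCC(=O)O)cc3Cl)ccc12`, is the next step from compound 2 on the shared core: chloro in place of fluoro on an aromatic carbon. Within the data shown here, only one measured step exists in this set, fluoro in place of hydrogen at the same place on the ring, and it shifted the maximal response by an amount that counts as noise. Among the measured compounds shown here, a further halogen swap at that place, from fluoro to chloro, has no direct precedent among the measured compounds, so the account expects no movement beyond the scatter in this assay, that is a number 5 percentage points lower from compound 2 to compound 3 (within the scatter). Compound 3 is therefore estimated to give 100% in this assay, with a range from 85% to 115%.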

Compound 3, largest response reached (reported as efficacy), in percent of the reference or control that the assay uses in the Free fatty acid receptor 1 assay: 102%
Beside the measured number, compound 3's estimate is 2 percentage points below it; the range from low to high includes it.
By their numbers in the Free fatty acid receptor 1 assay, from the lowest: compounds 1, 3 and 2 (each within the scatter of the next).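

At this place on the aromatic ring, ortho to a large group and meta to a 2-carboxyethyl group, chloro now stands as a second halogen, and in the Free fatty acid receptor 1 assay the swap from fluoro is a small step, a number 3 percentage points lower from compound 2 to compound 3 (within the scatter), while the step from the unsubstituted ring is a number 7 percentage points higher from compound 1 to compound 3 (within the scatter), so compounds 1, 2 and 3 all lie within the scatter of one another in maximal response. The second read-out does separate the two halogens: in a physicochemical assay for lipophilicity, using the shake flask method, measured as octanol-water partition, with a stated time of 30 min, at pH 7.4 (a lower number here means a more polar compound, a higher number a more lipophilic compound), compound 2 gives 2.9 and compound 3 gives 3.3, which is a number 0.40 log units higher from compound 2 to compound 3 (beyond the scatter). Chloro in place of fluoro at this place therefore makes the compound more lipophilic while the maximal response stays within the scatter, a change that the earlier pair, read in a single assay, could not show: the measured distribution coefficient of compound 2, 2.9, and of compound 3, 3.3, a number 0.40 log units higher (beyond the scatter)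

The three compounds leave open whether a larger or non-halogen group at this place, such as methyl, methoxy or trifluoromethyl, would also keep the maximal response. They also leave open how a longer chain in place of the 2-carboxyethyl group would behave in either assay.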